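The source may report more compounds than this note shows. Statements on the series, on what has been measured and on what is new or still open speak of the compounds shown alone.

Measured in a functional assay on cells (Neutrophil, Homo sapiens) for inhibition; on this read-out lower numbers stand for stronger inhibition and higher numbers for weaker inhibition: compound 1 `COc1ccc(-c2c(C)oc3cc(OC)c(O)cc23)cc1O` gives 0.33 ug/mL; compound 2 `COc1ccc([C@H]2Oc3cc(OC)c(OC)cc3[C@@H]2C)cc1O` gives 2.28 ug/mL; compound 3 `COc1ccc(-c2oc3cc(OC)c(O)cc3c2C)cc1O` gives 0.73 ug/mL.

Compound 2 stands at the highest number of the three. Its nearest neighbour is compound 3, whose number is lower by a gap beyond the scatter; compound 1 lies furthest, lower again by a gap beyond the scatter.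

Compound 4 `COc1ccc([C@H]2Oc3cc(OC)c(O)cc3[C@@H]2C)cc1O` differs from compound 2 by hydrogen in place of methyl on an oxygen on an aromatic ring. Within the data shown here, no measured pair shows this change on its own. Compounds 1 and 3 both carry hydroxy at that position and both give lower numbers than compound 2, but each differs from compound 2 elsewhere as well, so those gaps cannot be read as this step.

For compound 4 a modest step downward from compound 2 is expected, a 1.9-fold lower number from compound 2 to compound 4 (0.28 log units; within the scatter), possibly no larger than the scatter. The estimate for compound 4 in this assay is 1.2 ug/mL, within 0.5 ug/mL to 3 ug/mL.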

Compound 4, half-maximal inhibitory concentration: 0.69 ug/mL
Estimate against measurement, compound 4: 1.7-fold (0.24 log units) above; low and high end bracket the measured number.
By their numbers in this assay, from the lowest: compound 1; then compounds 4 and 3 (each within the scatter of the next); then compound 2.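

In this assay, the methoxy to hydroxy change at this oxygen on an aromatic ring can now be read on its own (a 3.3-fold lower number from compound 2 to compound 4 (0.52 log units; beyond the scatter)), and the gap lies beyond the scatter. Compounds 1 and 3 could not show this, as each differs from compound 2 elsewhere as well. Nothing shown accounts for the size of this step.

As far as these compounds go, whether a longer chain on that oxygen, such as ethoxy or an aminoethoxy group, would hold the number near either end of this step stays open. So does whether the same change would give a similar step on the cores of compound 1 and compound 3.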